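This account rests on a few compounds, and the source may have more. Where it says the series, first, only, none or still open, it means among the compounds named here.

Measured so far:
compound 1, `O=S(=O)(NCCNCc1cccc2ccccc12)c1cc(C(F)(F)F)cc(C(F)(F)F)c1`: 24000 nM
compound 2, `O=S(=O)(NCCCNCc1ccc(Cl)c(C(F)(F)F)c1)c1cc(C(F)(F)F)cc(C(F)(F)F)c1`: 10000 nM

Both were tested in a functional assay on PANC-1 cells (Homo sapiens) for inhibition, read by MTT assay, with a stated time of 72 h; on this read-out lower numbers stand for stronger inhibition of growth and higher numbers for weaker inhibition of growth. Compound 2, which gives 10000 nM, stands at the lowest of the two numbers; its nearest neighbour is compound 1, which gives 24000 nM, a gap that lies beyond the usual scatter. Among the measured compounds shown here, the two differ in more than one place, so their values alone show only that compound 2 inhibits growth more strongly.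

Compound 3, `O=S(=O)(NCCCNCc1ccc(Br)cc1)c1cc(C(F)(F)F)cc(C(F)(F)F)c1`, has not yet been measured in this assay. It differs from compound 2 in one place: 4-bromophenyl in place of 4-chloro-3-(trifluoromethyl)phenyl on a saturated chain carbon bound to an amine nitrogen. For the measured compounds named here, no pair of measured compounds shows this swap, so there is no measured step to lean on. The group that enters is smaller and carries fewer atoms than the one that leaves; a modest loss of inhibition is expected, and the step of a 2.0-fold higher number from compound 2 to compound 3 (0.30 log units; within the scatter) is the expected size and direction. Compound 3 is thus estimated at 20000 nM, within a range from 8000 nM to 50000 nM.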

Compound 3, concentration for 50% growth inhibition: 2200 nM
Beside the measured number, compound 3's estimate is 9.1-fold (0.96 log units) above it, and the stated range ends above it.
By their numbers in this assay, from the lowest: compound 3; then compound 2; then compound 1.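

In this assay, the group on a saturated chain carbon bound to an amine nitrogen clearly affects inhibition of growth: 4-bromophenyl in place of 4-chloro-3-(trifluoromethyl)phenyl gives a 4.5-fold lower number from compound 2 to compound 3 (0.66 log units; beyond the scatter), a change beyond the usual scatter. This position therefore does not need the larger group, since the entering group has fewer heavy atoms and still gives the stronger inhibition of the pair. Nothing measured here explains why this swap helps.

From the compounds shown here alone, it remains open whether the gain comes from the bromine or from losing the chlorine or the trifluoromethyl group, a question that 4-chlorophenyl or 3-(trifluoromethyl)phenyl at the same place could help to separate. Going by these compounds, compound 1 differs from both other compounds in more than one place, so the effect of chain length, including that of a longer chain, also remains open.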